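A few compounds are considered here, and "the series" means these few. Any claim that something is new, unique, unknown or untested is made for them only; others in the source may bear on it.

All three measured values come from a functional assay on HeLa cells (Homo sapiens); on this read-out higher numbers stand for an effect only at larger amounts of compound and lower numbers for an effect already at smaller amounts.

Compound 1, `NC(=O)c1cc(CCl)[nH]n1`, gives > 100 ug/mL, which is a limit of the assay and not a number.
Compound 2, `NC(=O)c1cc(CI)[nH]n1`, gives > 100 ug/mL, again a limit and not a number.
Compound 3, `CC(=O)OC[C@@H]1OC(n2nc(CCl)cc2C(N)=O)[C@@H](OC(C)=O)[C@H](OC(C)=O)[C@H]1OC(C)=O`, gives 18 ug/mL.

Compound 1 and compound 2 share one small core and differ in one place: iodo in place of chloro on a saturated chain carbon bound to an aromatic carbon. The step that the two limits leave unreadable from compound 1 to compound 2 has no readable size because the limit of > 100 ug/mL in this assay, at which 2 of the 3 values shown sit, leaves both of its values open. Compound 3 rests on a different and much larger core; the difference between the core of compound 1 and the core of compound 3 is not broken down here. Compound 3 is the only one of the three with a number rather than a limit in this assay.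

Compound 4, `CC(=O)OC[C@@H]1OC(n2nc(CI)cc2C(N)=O)[C@@H](OC(C)=O)[C@H](OC(C)=O)[C@H]1OC(C)=O`, has not yet been measured. It differs from compound 3 by iodo in place of chloro on a saturated chain carbon bound to an aromatic carbon, the same change made from compound 1 to compound 2, and at the same place. Since that earlier step gave no readable size, there is no measured guide to how large the step in this assay should be. The step from compound 3 to compound 4 is expected to stay small, no change at the digits printed from compound 3 to compound 4 (within the scatter), because compound 3 gives 18 ug/mL and only one halogen atom is exchanged. Compound 4 is therefore estimated to give about 18 ug/mL in this assay, with a likely range from 6 ug/mL to 55 ug/mL.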

Compound 4, concentration for half-maximal effect: 2 ug/mL
Beside the measured number, compound 4's estimate is 9.0-fold (0.95 log units) above it, outside the stated range (below it).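

On the larger core shared by compound 3 and compound 4, putting iodo in place of chloro on a saturated chain carbon bound to an aromatic carbon gives a 9.0-fold lower number from compound 3 to compound 4 (0.95 log units; beyond the scatter) in this assay, so in this pair the exchange of a single halogen atom has a measurable effect beyond the usual scatter. The same change on the small core, from compound 1 to compound 2, cannot be read, since neither compound gives a number there: the limit of > 100 ug/mL in this assay, at which 2 of the 4 values shown sit. The series therefore offers only one readable size for this change, and it does not show whether that size carries over from one core to the other: the step on the small core could be similar, smaller or larger, and this single pair on the larger core cannot settle which, nor can it explain why the step occurs.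

The compounds shown leave open how bromomethyl or aminomethyl, each placed where chloromethyl and iodomethyl stand, would read in this assay, and so whether the result extends beyond these two halogens. Also open, on these data alone, is how the larger core would respond if its acetate esters gave way to free hydroxyl groups.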